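A Fluorobenzyl Ether Against Two Close Values

The source may hold more compounds than are shown below. What is called first, only, known or untested is meant among the compounds shown, and "the series" means these compounds.

Measured in a functional assay on J774.A1 cells (Mus musculus) for inhibition, read by Griess assay, with stated times of 1 h and 24 h; on this read-out higher numbers stand for weaker inhibition and lower numbers for stronger inhibition:
- Compound 1 `CC(C)=CCOc1ccccc1C1CC(=O)c2ccccc2O1`: 34300 nM
- Compound 2 `COc1ccccc1C1CC(=O)c2ccccc2O1`: 44500 nM

Only these two compounds have been measured, and compound 2, at 44500 nM, cannot be told apart from compound 1, since the gap between them lies within the scatter. The next compound, compound 3 `O=C1CC(c2ccccc2OCc2cccc(F)c2)Oc2ccccc21`, changes compound 2 in one place: 3-fluorophenyl in place of hydrogen on a saturated chain carbon bound to an oxygen on an aromatic ring. In words, 3-fluorophenyl stands in place of hydrogen on a saturated chain carbon bound to an oxygen on an aromatic ring. The same difference, cut one bond further out, reads methyl to 3-fluorobenzyl.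

Among the compounds with values here, one measured step bears on this place: a 1.3-fold higher number from compound 1 to compound 2 (0.11 log units; within the scatter). It puts hydrogen in place of 2-methylprop-1-en-1-yl on the same kind of carbon. That single step is thin evidence, and neither measured compound carries a 3-fluorophenyl group. Even so, no step beyond the scatter is expected in this assay, and no direction can be favoured. The expected step is a 1.4-fold lower number from compound 2 to compound 3 (0.14 log units; within the scatter). The estimate for compound 3 is 32000 nM, with an expected range of 13000 nM to 70000 nM.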

Compound 3, half-maximal inhibitory concentration: 13200 nM
The estimate for compound 3 lay 2.4-fold (0.38 log units) above the measured number; low and high end bracket the measured number.
By their numbers in this assay, from the lowest: compound 3; then compounds 1 and 2 (each within the scatter of the next).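

In this assay the place on the saturated chain carbon bound to an oxygen on an aromatic ring now proves able to shift the number beyond the scatter, which the earlier pair had not shown: the change from hydrogen to 3-fluorophenyl gives a 3.4-fold lower number from compound 2 to compound 3 (0.53 log units; beyond the scatter) and stays in the same direction when 3-fluorophenyl replaces 2-methylprop-1-en-1-yl, with a 2.6-fold lower number from compound 1 to compound 3 (0.41 log units; beyond the scatter) as the result. Not every group at this place separates from hydrogen, for 2-methylprop-1-en-1-yl and hydrogen remain apart by only a 1.3-fold higher number from compound 1 to compound 2 (0.11 log units; within the scatter) in a step within the scatter, so among these three groups only 3-fluorophenyl, the one carrying an aromatic ring, stands apart, and both of its steps are modest in size. Nothing at hand accounts for this shift.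

The compounds shown leave open whether the fluorine takes any part in the step or whether a plain phenyl at this place would read the same, and whether 4-fluorophenyl or 2-fluorophenyl would match 3-fluorophenyl. Also open, on these data alone, is how a group of another kind on the same carbon, such as a carboxylic acid, an amine or a longer chain, would stand against these three.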